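This account rests on a few compounds, and the source may have more. Where it says the series, first, only, none or still open, it means among the compounds named here.

Measured compounds:
Compound 1 `C[C@]1(O)CC(=O)OC(CSc2nc(-c3ccccc3)c(-c3ccccc3)[nH]2)C1` gives 140 nM in an assay on microsomes from liver for inhibition of sterol O-acyltransferase 1 (Rattus norvegicus); a lower number here means a stronger inhibitor, a higher number a weaker inhibitor.
Compound 2 `Cn1c(SC[C@H]2C[C@@](C)(O)CC(=O)O2)nc(-c2ccccc2)c1-c1ccccc1.Cn1c(SC[C@H]2C[C@](C)(O)CC(=O)O2)nc(-c2ccccc2)c1-c1ccccc1` gives 2600 nM in this assay.
Compound 3 `CC1=CC(=O)OC(CSc2nc(-c3ccccc3Cl)c(-c3ccccc3Cl)[nH]2)C1` gives 1700 nM in this assay.

Compound 1 has the lowest number of the three and is the strongest inhibitor of the set, since its gaps to compound 3 and to compound 2 both lie beyond the scatter. Compound 4 `CO[C@H]1C[C@H](O)C[C@@H](CSc2nc(-c3ccccc3)c(-c3ccccc3)[nH]2)O1` has not been measured. It differs from compound 1 in one place: a group of 9 heavy atoms (6 carbon, 3 oxygen; one six-membered non-aromatic ring with 1 hetero atom) in place of a group of 9 heavy atoms (6 carbon, 3 oxygen; one six-membered non-aromatic ring with 1 hetero atom), on a saturated chain carbon bound to a sulfur. Among the measured compounds shown here, no measured pair differs in one place, so the size of such a change cannot be read from the data. The double bond outside aromatic rings is lost while the six-membered ring with one hetero atom is kept, and a moderate weakening in this assay is expected, somewhat beyond the scatter. For compound 4 the expected step is a 2.9-fold higher number from compound 1 to compound 4 (0.46 log units; beyond the scatter). Compound 4 is estimated at 400 nM, within a range of 120 nM to 1500 nM.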

Compound 4, half-maximal inhibitory concentration: 90 nM
Compound 4: the middle estimate sits 4.4-fold (0.65 log units) above what was measured; measured number outside the range, below it.
By their numbers in this assay, from the lowest: compounds 4 and 1 (each within the scatter of the next); then compounds 3 and 2 (each within the scatter of the next).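

In this assay, among the compounds shown here, the exchange on a saturated chain carbon bound to a sulfur gives a 1.6-fold lower number from compound 1 to compound 4 (0.19 log units; within the scatter) and is the only step that can be read at this position. Compounds 1 and 4 therefore cannot be told apart, although the double bond outside aromatic rings is lost and the number of defined stereocentres rises from 1 to 3 while a six-membered non-aromatic ring with 1 hetero atom is kept. No available evidence bears on this result. The compounds shown leave open how an amine or a carboxylic acid on this ring would read. They also leave open what each stereocentre of compound 4 contributes.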